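This account rests on a few compounds, and the source may have more. Where it says the series, first, only, none or still open, it means among the compounds named here.

In an ADME assay on H9c2 cells (Rattus norvegicus) for cytotoxicity, read by resazurin assay, with a stated time of 72 h (on this read-out lower numbers stand for higher toxicity in this test and higher numbers for lower toxicity in this test), compound 1 `C/C(=N\Nc1nc(C)cs1)c1ccc(Cl)c(Cl)c1` gives 26100 nM. Compound 2 `C/C(=N\Nc1nc(C)c(C)s1)c1ccc(Cl)c(Cl)c1` reads > 50000 nM, which is a limit of the assay and not a number. Compound 3 `C/C(=N\Nc1nc(-c2ccccc2)cs1)c1ccc(Cl)c(Cl)c1` reads > 50000 nM, which is also only a limit. Compound 4 `C/C(=N\Nc1nc(-c2ccccc2)c(C)s1)c1ccc(Cl)c(Cl)c1` differs from it as follows: methyl in place of hydrogen on an aromatic carbon. The same kind of change, methyl in place of hydrogen on an aromatic carbon, gave an at least 1.9-fold higher number from compound 1 to compound 2 (0.28 log units; that floor lies within the scatter). Phenyl in place of methyl on an aromatic carbon gave an at least 1.9-fold higher number from compound 1 to compound 3 (0.28 log units; that floor lies within the scatter). Neither step shows a change beyond the scatter, so no step beyond the scatter is expected here, and the estimate is a number no higher from compound 3 to compound 4 (the limit leaves the size open). For compound 4, the estimated value is 50000 nM, with an expected range of 25000 nM to 100000 nM.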

Compound 4, half-maximal cytotoxic concentration: > 50000 nM
Compound 4: a limit, no number (the forecaster's own chance of this, stated with the estimate: 70%); the middle value sits exactly at the limit.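

The steps from compound 2 and compound 3 to compound 4 cannot be read, because all three compounds sit at the same limit: the limit of > 50000 nM in this assay, at which 3 of the 4 values shown sit. Whether methyl or phenyl changes the number among these three compounds in this assay stays open.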